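This account rests on a few compounds, and the source may have more. Where it says the series, first, only, none or still open, it means among the compounds named here.

Measured so far:
- compound 1, `O=C(Nc1cccc(-n2cc(-c3ccncc3)c(-c3ccc(Cl)c(O)c3)n2)c1)Nc1cccc(C(F)(F)F)c1`, 7260 nM in a functional assay on HCC 2998 cells (Homo sapiens) for inhibition, read by sulforhodamine B assay, with a stated time of 48 h; a higher number here means a weaker inhibitor of growth, a lower number a stronger inhibitor of growth
- compound 2, `O=C(Nc1cccc(-n2cc(-c3ccncc3)c(-c3ccc(Cl)c(O)c3)n2)c1)Nc1ccc(Cl)c(Cl)c1`, 2890 nM
- compound 3, `COc1cc(-c2nn(-c3cccc(NC(=O)Nc4cccc(C(F)(F)F)c4)c3)cc2-c2ccncc2)ccc1Cl`, 1190 nM

Compound 1 gives the highest of the three numbers in this assay. Its nearest neighbour is compound 2, with a 2.5-fold lower number from compound 1 to compound 2 (0.40 log units; beyond the scatter), and the furthest is compound 3, with a 6.1-fold lower number from compound 1 to compound 3 (0.79 log units; beyond the scatter). Compound 4, `O=C(Nc1cccc(-n2cc(-c3ccncc3)c(-c3ccc(Cl)c(O)c3)n2)c1)Nc1cc(C(F)(F)F)cc(C(F)(F)F)c1`, differs from compound 1 by trifluoromethyl in place of hydrogen on an aromatic carbon. Among the measured compounds shown here, only the step from compound 1 to compound 2 touches the same aryl ring of the urea, and it was modest; the step to compound 3 concerns a different part of the molecule. A modest lowering is therefore expected, a 1.8-fold lower number from compound 1 to compound 4 (0.26 log units; within the scatter), with little confidence that it exceeds the scatter. Compound 4 is estimated at 4000 nM, between 1500 nM and 12000 nM.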

Compound 4, concentration for 50% growth inhibition: 1030 nM
The estimate for compound 4 lay 3.9-fold (0.59 log units) above the measured number, and the stated range ends above it.
By their numbers in this assay, from the lowest: compounds 4 and 3 (each within the scatter of the next); then compound 2; then compound 1.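

In this assay, placing trifluoromethyl on this aromatic carbon, meta to a trifluoromethyl group, gives a 7.0-fold lower number from compound 1 to compound 4 (0.85 log units; beyond the scatter). Unlike the earlier change on this ring, which replaced the substitution pattern of compound 1, this one keeps the existing trifluoromethyl group and adds a second, showing that the added group alone lowers the number beyond the scatter. Nothing available explains this step.

From the compounds shown here alone, whether a nitrile or an amine on the same carbon would also lower the number remains open. So does whether this change would add to the effect of methyl on the oxygen in compound 3.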